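The source may hold more compounds than are shown below. What is called first, only, known or untested is meant among the compounds shown, and "the series" means these compounds.

Measured so far:
compound 1 `C[C@@H]1CN(c2cccc3c2C[C@H](CN(C)[C@H]2CCCc4cccnc42)NC3)C[C@H](C)N1`: 100%
compound 2 `Cc1cnc(CN(C)C[C@H]2Cc3c(cccc3N3CCNCC3)CN2)c(C)c1`: "not determined" (no result reported)

For the measured compounds named here, in an ADME assay on microsomes from liver (Homo sapiens) for metabolic stability, read by LC-MS, with a stated time of 10 min (a lower number here means that less of the compound is left, a higher number that more of the compound is left), compound 1 gives 100%, the only number available. Going by the values given here, compound 2 has no reported result, so there is no measured pair to compare and no step to learn from. Compound 3 `CC(C)N1CCN(c2cccc3c2C[C@H](CN(C)[C@H]2CCCc4cccnc42)NC3)CC1` keeps the shared core of compound 1 and changes one group, with 4-isopropylpiperazin-1-yl in place of 3,5-dimethylpiperazin-1-yl on an aromatic carbon. Compound 1 already stands at 100%, so any real change can only run downward. Among the compounds with values here, no measured example of this swap exists, which leaves the size of the change uncertain, and a result within the usual scatter remains possible. A moderate drop is expected, the estimated a number 20 percentage points lower from compound 1 to compound 3 (beyond the scatter). For compound 3 the estimated value is 80%, with an expected range from 55% to 100%.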

Compound 3, percent of the compound remaining: 56.6%
Compound 3: middle estimate off by 23.4 percentage points, on the high side, and the stated range covers the measured number.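

In this assay the change to 4-isopropylpiperazin-1-yl in place of 3,5-dimethylpiperazin-1-yl on an aromatic carbon gives a number 43.4 percentage points lower from compound 1 to compound 3 (beyond the scatter) and so shows that the group at this position matters for how much compound survives. The swap alters several things at once: the entering group has 9 heavy atoms against 8 and 0 hydrogen-bond donors against 1, while the leaving group has 2 defined stereocentres. Nothing shown ties the loss to any one of these differences.

Still open, from the compounds shown here alone, is whether a 4-methylpiperazin-1-yl, an unsubstituted piperazin-1-yl or a morpholin-4-yl group at this place would stay close to compound 1 or fall towards compound 3. Changes elsewhere on the shared core also remain unresolved, and compound 2 offers no number to help.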